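From Nitro to Bromo on a Shared Core

The source may report more compounds than this note shows. Statements on the series, on what has been measured and on what is new or still open speak of the compounds shown alone.

In a functional assay on HepG2 cells (Homo sapiens) for antiproliferative activity, read by fluorescence and resazurin assay, with a stated time of 48 h (a lower number here means a stronger inhibitor, a higher number a weaker inhibitor), compound 1 `Cc1noc(NS(=O)(=O)c2ccc(NC(=O)c3cc4ccccc4oc3=O)cc2)c1C` gives 24000 nM, and compound 2 `Cc1noc(NS(=O)(=O)c2ccc(NC(=O)c3cc4cc([N+](=O)[O-])ccc4oc3=O)cc2)c1C` gives 15000 nM. These two numbers lie within the scatter of each other, so compound 2 cannot be ranked apart from compound 1. Compound 3 `Cc1noc(NS(=O)(=O)c2ccc(NC(=O)c3cc4cc(Br)ccc4oc3=O)cc2)c1C` has bromo in place of nitro on an aromatic carbon. For the measured compounds named here, only one measured step bears on this change: a 1.6-fold lower number from compound 1 to compound 2 (0.20 log units; within the scatter), with nitro in place of hydrogen on an aromatic carbon. Going by the values given here, that step stays within the scatter, and no measurement yet shows what bromo does. Removing nitro is therefore expected to leave the number in this assay within the scatter, with no favoured direction. The expected step is no change at the digits printed from compound 2 to compound 3 (within the scatter). For compound 3 the estimated value is 15000 nM, with an expected range from 7000 nM to 32000 nM.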

Compound 3, half-maximal inhibitory concentration: 8800 nM
Compound 3: the middle estimate sits 1.7-fold (0.23 log units) above what was measured, within the range that was stated.
By their numbers in this assay, from the lowest: compounds 3, 2 and 1 (each within the scatter of the next, the first and the last beyond it).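

Of the two groups shown at this position on the shared core, only bromo separates from hydrogen in this assay, with a 2.7-fold lower number from compound 1 to compound 3 (0.44 log units; beyond the scatter) against the unsubstituted compound, a modest step beyond the scatter. Nitro did not show such a separation, yet the direct exchange gives a 1.7-fold lower number from compound 2 to compound 3 (0.23 log units; within the scatter) and stays within the scatter, so compound 3 cannot be ranked apart from compound 2 even though only compound 3 stands apart from compound 1. Nothing measured here accounts for the step from hydrogen to bromo.

As far as these compounds go, whether chloro, iodo, methoxy or an amine at this aromatic carbon would give a number like that of bromo remains open. So does whether the step from hydrogen to bromo would persist with a different group elsewhere on the shared core.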